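The source may report more compounds than this note shows. Statements on the series, on what has been measured and on what is new or still open speak of the compounds shown alone.

Compound 1 `Cc1c(Cc2ccc(-c3ccc(F)cc3)cc2)c(=O)oc2cc(OCC(O)CN3CCC(C(N)=O)CC3)ccc12`: 19300 nM
Compound 2 `Cc1c(Cc2ccccc2)c(=O)oc2cc(OCC(CN3CCC(C(N)=O)CC3)Oc3ccc(F)cc3)ccc12`: 66400 nM

In an ADME assay on A549 cells (Homo sapiens) for cytotoxicity, read by CellTiter-Glo (on this read-out lower numbers stand for higher toxicity in this test and higher numbers for lower toxicity in this test), compound 1 gives 19300 nM, and compound 2 gives 66400 nM, the higher of the two numbers; the gap between them lies beyond the scatter. For the measured compounds named here, compound 3 `Cc1c(Cc2ccccc2)c(=O)oc2cc(OCC(CN3CCC(C(N)=O)CC3)Oc3ccc([N+](=O)[O-])cc3)ccc12` differs from compound 2 by nitro in place of fluoro on an aromatic carbon; no measured pair shows this exchange. The step from compound 2 to compound 3 in this assay is expected to be small, in either direction, and within the scatter. Compound 3 is estimated at 50000 nM, within a range from 20000 nM to 130000 nM, meaning an expected step of a 1.3-fold lower number from compound 2 to compound 3 (0.12 log units; within the scatter).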

Compound 3, half-maximal cytotoxic concentration: 94800 nM
Compound 3: middle estimate off by 1.9-fold (0.28 log units), on the low side, and the stated range covers the measured number.
By their numbers in this assay, from the lowest: compound 1; then compounds 2 and 3 (each within the scatter of the next).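

In this assay, nitro in place of fluoro on the phenoxy ring gives a 1.4-fold higher number from compound 2 to compound 3 (0.15 log units; within the scatter). At this place on the ring, then, the two groups cannot be told apart in this test, even though nitro brings more heavy atoms and two hydrogen-bond acceptors. Nothing measured here offers an explanation for this result.

On these data alone, whether an amine or a carboxylic acid at the same place would also leave the number within the scatter remains open. A single exchange cannot establish a trend for this position.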